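The source may hold more compounds than are shown below. What is called first, only, known or untested is meant among the compounds shown, and "the series" means these compounds.

Measured in a physicochemical assay for activation, in phosphate buffer, at pH 7.4, in the presence of a further agent that is not named here; a higher number here means that the compound lasts longer, a lower number that the compound disappears faster:

Compound 1 `Cc1cc(C(N)=S)c(C)cc1O`: 0.0683 h
Compound 2 `NC(=S)c1cc2ccccc2[nH]1`: 0.153 h
Compound 3 `NC(=S)c1ccc(O)cc1F`: 0.0367 h

Of the three thioamides measured so far, compound 3 `NC(=S)c1ccc(O)cc1F` returns a half-life that sits within the scatter of compound 1, so the two cannot be ordered against each other; against compound 2 it lies clearly lower, beyond the scatter. Compound 2 is thus the one that lasts longest among these three, while compound 1 and compound 3 disappear at rates that this assay cannot tell apart.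

The next compound, compound 4 `NC(=S)c1ccc(O)cc1Cl`, is related to compound 3 by a single substitution: chloro in place of fluoro on an aromatic carbon. Among the measured compounds shown here, no pair of measured compounds shows this kind of halogen exchange, so there is no measured step to lean on. Both halogens are single heavy atoms with no donors or acceptors, and the rest of the structure is unchanged, so the step from compound 3 to compound 4 is expected to be small, a 1.1-fold higher number from compound 3 to compound 4 (0.06 log units; within the scatter), most likely not beyond the scatter in either direction. For compound 4 the expected half-life is 0.042 h, with a range from 0.018 h to 0.1 h.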

Compound 4, half-life: 0.0433 h
Compound 4: middle estimate off by 1.0-fold (0.01 log units), on the low side; low and high end bracket the measured number.
By their numbers in this assay, from the lowest: compounds 3, 4 and 1 (each within the scatter of the next); then compound 2.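

Chloro in place of fluoro on this aromatic carbon, ortho to a group of 3 heavy atoms and meta to a hydroxy group, gives a 1.2-fold higher number from compound 3 to compound 4 (0.07 log units; within the scatter) in this assay. Among the compounds shown here, this is the first single-place step, and at this position it does not separate the two halogens: a heavier halogen atom here leaves the half-life indistinguishable from that of the fluoro compound. No supporting measurement bears on the reason for this result.

The compounds shown leave open whether a methoxy group, an amine or a carboxylic acid on this aromatic carbon would stay within the scatter of compound 3 or move beyond it. Also open, from the compounds shown here alone, is what a plain hydrogen at this carbon would give, and so whether either halogen matters here at all.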